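The source may report more compounds than this note shows. Statements on the series, on what has been measured and on what is new or still open speak of the compounds shown alone.

Measured so far in a functional assay on HBL-100 cells (Homo sapiens) for inhibition, read by sulforhodamine B assay, with a stated time of 48 h; a higher number here means a weaker inhibitor of growth, a lower number a stronger inhibitor of growth:
- compound 1 `Cc1cc(=O)oc2cc(N=C=[Se])ccc12`: 5000 nM
- compound 2 `COC(=[Se])Nc1ccc2c(C)cc(=O)oc2c1`: > 100000 nM (a limit)

Compound 2 stands at > 100000 nM, which is a limit of this assay and not a number. Its exact place is therefore unknown. Compound 3 `CCOC(=[Se])Nc1ccc2c(C)cc(=O)oc2c1` has not yet been measured. It differs from compound 2 by methyl in place of hydrogen on a saturated chain carbon bound to an oxygen on an unsaturated carbon, or methoxy to ethoxy. Going by the values given here, only one measured step bears on this, and only indirectly: an at least 20-fold higher number from compound 1 to compound 2 (1.30 log units; beyond the scatter). That step is large, but it concerns a different change and gives no direction for this one. No step beyond the scatter is therefore expected in this assay, in either direction, and another limit reading is quite possible. The expected change is a number no higher from compound 2 to compound 3 (the limit leaves the size open). For compound 3 the estimated value is 100000 nM, with an expected range from 30000 nM to 300000 nM.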

Compound 3, concentration for 50% growth inhibition: > 100000 nM
Compound 3: only a limit was reported; the forecaster's own chance of this, stated with the estimate: 70%; the middle value lies on the limit itself.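

In this assay, the large step seen with methoxy recurs with ethoxy, as the comparison gives an at least 20-fold higher number from compound 1 to compound 3 (1.30 log units; beyond the scatter). The step between the methoxy and ethoxy compounds cannot be read, so the change from methyl to ethyl can be neither ranked nor sized. What it does show is that methyl in place of hydrogen on this saturated chain carbon did not bring a reading inside the range of the assay, and the pair ends at one ceiling: the limit of > 100000 nM in this assay, at which 2 of the 3 values shown sit.

Going by these compounds, how far compound 2 and compound 3 lie beyond that limit stays open, and so does any order between them. The compounds shown also leave open whether a longer chain on the oxygen, or an amine in place of that alkoxy group, would return a measurable value.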